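Sulfamoyl in Place of Methylamino on the Shared Core

This account rests on a few compounds, and the source may have more. Where it says the series, first, only, none or still open, it means among the compounds named here.

Three compounds share one core. Compound 1 `NS(=O)(=O)c1ccc(Nc2nccc(-c3cccnc3)n2)cc1` carries sulfamoyl and gives 200 nM in a functional assay for inhibition, with Homo sapiens as the target; on this read-out lower numbers stand for stronger inhibition and higher numbers for weaker inhibition. Compound 2 `c1ccc(-c2ccnc(Nc3ccc(-n4ccnc4)cc3)n2)nc1` carries 1H-imidazol-1-yl and gives 1400 nM in this assay. Compound 3 `CNc1ccc(Nc2nccc(-c3ccccn3)n2)cc1` carries methylamino and gives 1400 nM in this assay; it stands level with compound 2 and the two together hold the highest numbers of the three, while compound 1 sits clearly lower. Within the data shown here, the only single step measured is the one no change at the digits printed from compound 2 to compound 3 (within the scatter), a swap on the same aromatic carbon that left the number where it was.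

Compound 4 `NS(=O)(=O)c1ccc(Nc2nccc(-c3ccccn3)n2)cc1` is compound 3 with sulfamoyl in place of methylamino on an aromatic carbon. Among the measured compounds shown here, no measured step bears on this exact exchange, and compound 1 differs from compound 3 in two places, so compound 3 at 1400 nM set against compound 1 at 200 nM only hints that sulfamoyl at this position goes with a lower number. The expected step of a 3.5-fold lower number from compound 3 to compound 4 (0.54 log units; beyond the scatter) is therefore a drop, with wide uncertainty. Compound 4 is estimated at 400 nM, within 130 nM to 1500 nM.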

Compound 4, half-maximal inhibitory concentration: 4600 nM
Compound 4: the middle estimate sits 12-fold (1.06 log units) below what was measured; measured number above the stated range.
By their numbers in this assay, from the lowest: compound 1; then compounds 2 and 3 (each within the scatter of the next); then compound 4.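

With pyridin-2-yl on the shared core, sulfamoyl does not bring the number down in this assay: the exchange for methylamino gives a 3.3-fold higher number from compound 3 to compound 4 (0.52 log units; beyond the scatter) and the exchange for 1H-imidazol-1-yl gives a 3.3-fold higher number from compound 2 to compound 4 (0.52 log units; beyond the scatter) on the same aromatic carbon, so sulfamoyl parts from two groups that stand level there. The low number of compound 1 therefore does not follow from sulfamoyl alone, since keeping sulfamoyl and putting pyridin-2-yl in place of pyridin-3-yl gives a 23-fold higher number from compound 1 to compound 4 (1.36 log units; beyond the scatter) as a large step. Nothing measured here accounts for either rise.

From the compounds shown here alone, whether methylamino or 1H-imidazol-1-yl would respond in the same way to pyridin-3-yl remains open, as the two pyridinyl groups can be compared only with sulfamoyl present. Going by these compounds, how a primary amine or a carboxylic acid would read on this aromatic carbon also remains open.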